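Tetrazole to Carboxypropoxy on a Quinoline Ether Core

The source may hold more compounds than are shown below. What is called first, only, known or untested is meant among the compounds shown, and "the series" means these compounds.

compound 1 `c1ccc2nc(COc3ccc(Cc4nnn[nH]4)cc3)ccc2c1`: 275 nM
compound 2 `CCOC(=O)CCCOc1cccc(OCc2ccc3ccccc3n2)c1`: 160 nM

In an assay on isolated protein for binding affinity to cysteinyl leukotriene receptor 1 (Cavia porcellus) (on this read-out higher numbers stand for weaker inhibition and lower numbers for stronger inhibition), compound 1 gives 275 nM, the higher of the two numbers, while compound 2 gives 160 nM, a difference that stays within the usual scatter. Compound 3 `O=C(O)CCCOc1ccc(OCc2ccc3ccccc3n2)cc1` is derived from compound 1 by 3-carboxypropoxy in place of (1H-tetrazol-5-yl)methyl on an aromatic carbon. Among the measured compounds shown here, no step between two measured compounds is available to guide this change. Compound 3 is expected to come out near the measured pair, with a step of a 1.8-fold lower number from compound 1 to compound 3 (0.26 log units; within the scatter) in this assay, a small move toward a lower number or none beyond the scatter. Compound 3 is estimated at 150 nM, within 40 nM to 600 nM.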

Compound 3, inhibition constant: 1200 nM
Compound 3: the middle estimate sits 8.0-fold (0.90 log units) below what was measured; measured number above the stated range.
By their numbers in this assay, from the lowest: compounds 2 and 1 (each within the scatter of the next); then compound 3.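

On this position, para to a large group, the exchange is not neutral: 3-carboxypropoxy in place of (1H-tetrazol-5-yl)methyl gives a clear loss in this assay (a 4.4-fold higher number from compound 1 to compound 3 (0.64 log units; beyond the scatter)). This is the only step among the compounds shown that reads this change on the shared core, and it is a modest one. No measurement shown here accounts for this step.

Still open, on these data alone, is whether an amide or a longer chain ending in a carboxylic acid at this position would return the number to that of compound 1. As far as these compounds go, it also remains open whether the same exchange would give a step of similar size on another core.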